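Chloro Added to Two Cores in a Dopamine Receptor Assay

This account rests on a few compounds, and the source may have more. Where it says the series, first, only, none or still open, it means among the compounds named here.

Compound 1, `Cc1cccc(NC(=O)CN2CCC(c3ccccc3)CC2)c1`, gives 2 nM in a functional assay on cells for antagonist activity at D(4) dopamine receptor (Homo sapiens), read by TR-FRET and cAMP accumulation, with a stated time of 30 min; on this read-out lower numbers stand for stronger inhibition and higher numbers for weaker inhibition.
Compound 2, `Cc1cccc(NC(=O)CN2CCC(c3ccc(Cl)cc3)CC2)c1`, gives 70200 nM in this assay.
Compound 3, `O=C(CN1CCN(c2ccccn2)CC1)Nc1cncnc1`, reaches only a limit of the assay in this assay: > 100000 nM.

The step from compound 1 to compound 2 is a single change, (chloro in place of hydrogen on an aromatic carbon), and it gives a 35000-fold higher number from compound 1 to compound 2 (4.55 log units; beyond the scatter). The same kind of change separates compound 3 from the not yet measured compound 4, `O=C(CN1CCN(c2ccc(Cl)cn2)CC1)Nc1cncnc1`, namely (chloro in place of hydrogen on an aromatic carbon). The surroundings are not the same, however: in compound 1 the hydrogen sits on a six-membered aromatic ring of carbon only, whereas in compound 3 it sits on a six-membered aromatic ring with one nitrogen, two atoms from the ring nitrogen. How the core of compound 1 differs from the core of compound 3 is not broken down here.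

What compound 3 offers as a starting point is a limit rather than a number, (the limit of > 100000 nM in this assay, at which 1 of the 3 values shown sits), so there is no measured value from which a worsening of the kind seen between compound 1 and compound 2 could be counted. The expectation for compound 4 is therefore that it stays at or near that limit, an estimated step of a number no higher from compound 3 to compound 4 (the limit leaves the size open) in this assay. For compound 4 the estimated value in this assay is 100000 nM, expected to fall between 50000 nM and 200000 nM.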

Compound 4, half-maximal inhibitory concentration: > 100000 nM
Compound 4: no number, only a limit; the forecaster's own chance of this, stated with the estimate: 85%; the middle value lies on the limit itself.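

In this assay compound 4 gives > 100000 nM, which is a limit of the assay and not a number. Among these compounds, compound 3 stands at the same limit, so no step between compound 3 and compound 4 can be read: the limit of > 100000 nM in this assay, at which 2 of the 4 values shown sit. The compounds shown leave open whether chloro in place of hydrogen changes anything on the core of compound 3, as it did on the core of compound 1.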